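Adding a Second Chlorine Where One Chlorophenyl Gave Only a Limit

The source may report more compounds than this note shows. Statements on the series, on what has been measured and on what is new or still open speak of the compounds shown alone.

Three measured compounds share one core and differ only in where a single chlorine sits on the phenyl ring attached to the carbon with a double bond to nitrogen. Compound 1 `C/C(=N\NC(=O)CSc1nnnn1C)c1ccccc1Cl` carries a 2-chlorophenyl group, and in a functional assay on A549 cells (Homo sapiens) for cytotoxicity, read by XTT assay, with a stated time of 24 h (on this read-out lower numbers stand for stronger inhibition and higher numbers for weaker inhibition), compound 1 gives 6320000 nM. Compound 3 `C/C(=N\NC(=O)CSc1nnnn1C)c1ccc(Cl)cc1` carries a 4-chlorophenyl group, and in this assay compound 3 gives 6000000 nM. Compound 2 `C/C(=N\NC(=O)CSc1nnnn1C)c1cccc(Cl)c1` carries a 3-chlorophenyl group; in this assay compound 2 reaches only a limit of the assay, > 10000000 nM. The two steps that touch it, an at least 1.5-fold higher number from compound 1 to compound 2 (0.19 log units; that floor lies within the scatter) and an at least 1.6-fold lower number from compound 2 to compound 3 (0.22 log units; that floor lies within the scatter), both rest on that floor and stay within the scatter. Compound 4 `C/C(=N\NC(=O)CSc1nnnn1C)c1cc(Cl)ccc1Cl` differs from compound 2 by chloro in place of hydrogen on an aromatic carbon, placed ortho to the large group and para to the existing chloro group. Among the measured compounds shown here, because compound 2 sits at the limit of > 10000000 nM in this assay, at which 1 of the 3 values shown sits, no measured step can show a direction for this change. Compound 4 is expected to give about 7000000 nM in this assay, between 3000000 nM and 15000000 nM. That estimate means an expected step of an at least 1.4-fold lower number from compound 2 to compound 4 (0.15 log units; that floor lies within the scatter), no larger than the scatter.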

Compound 4, half-maximal inhibitory concentration: 1500000 nM
Beside the measured number, compound 4's estimate is 4.7-fold (0.67 log units) above it; the measured number lies below the stated range.
By their numbers in this assay, from the lowest: compound 4; then compounds 3 and 1 (each within the scatter of the next). At a limit, above all of these: compound 2.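

In this assay, chloro in place of hydrogen on this aromatic carbon, ortho to a large group and para to a chloro group, now has a direction that can be read: the step is an at least 6.6-fold lower number from compound 2 to compound 4 (0.82 log units; beyond the scatter). Among the compounds shown here, the change also shows against the other single-chlorine compound, with a 4.2-fold lower number from compound 1 to compound 4 (0.62 log units; beyond the scatter), so a second chlorine gives a step beyond the scatter, whereas moving the single chlorine around the ring gave no step printed as beyond it. The first of these steps gives only a floor for the size of the change, so its true size stays unknown: the limit of > 10000000 nM in this assay, at which 1 of the 4 values shown sits.

From the compounds shown here alone, whether a second chlorine elsewhere on the ring would lower the number as well stays open. So does whether a different group at this position, such as a methoxy group or an amine, would give a step of similar size.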